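Ethyl gives way to tert-butyl in compound 3

The source may report more compounds than this note shows. Statements on the series, on what has been measured and on what is new or still open speak of the compounds shown alone.

Compound 1 `CC1=NC(C)=C([N+](=O)[O-])C(c2ccccn2)/C1=C(\O)OC1CCCC1`: 19800 nM
Compound 2 `CCO/C(O)=C1\C(C)=NC(C)=C([N+](=O)[O-])C1c1ccccn1`: 22800 nM

Within the data shown here, in a functional assay (cardiac atrium) for agonist activity, with Cavia porcellus as the target (a lower number here means that less compound is needed, a higher number that more compound is needed for the effect), compound 2 gives 22800 nM, within the scatter of the only other measured compound. Compound 3 `CC1=NC(C)=C([N+](=O)[O-])C(c2ccccn2)/C1=C(\O)OC(C)(C)C` has tert-butyl in place of ethyl on an oxygen on an unsaturated carbon. Among the measured compounds shown here, one measured step bears on this change, at the same place: a 1.2-fold higher number from compound 1 to compound 2 (0.06 log units; within the scatter), with ethyl in place of cyclopentyl. That single step is slim evidence, but no shift beyond the scatter is expected in this assay, in either direction. The expected step is a 1.1-fold lower number from compound 2 to compound 3 (0.04 log units; within the scatter). For compound 3 the estimated value is 21000 nM, with an expected range of 9000 nM to 48000 nM.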

Compound 3, half-maximal effective concentration: 1810000 nM
Compound 3: middle estimate off by 86-fold (1.94 log units), on the low side; measured number above the stated range.
By their numbers in this assay, from the lowest: compounds 1 and 2 (each within the scatter of the next); then compound 3.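

At this position, on an oxygen on an unsaturated carbon, the group is not freely exchangeable in this assay: tert-butyl gives a 79-fold higher number from compound 2 to compound 3 (1.90 log units; beyond the scatter) and a 91-fold higher number from compound 1 to compound 3 (1.96 log units; beyond the scatter) in the same direction. Ethyl and cyclopentyl, a chain and a ring, read alike, and tert-butyl alone stands apart, so the earlier flat step did not hold for every group here. On these data alone, whether isopropyl or a longer chain such as n-butyl on this oxygen would stay with ethyl or follow tert-butyl remains open. Nothing given here explains the jump.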